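The source may report more compounds than this note shows. Statements on the series, on what has been measured and on what is new or still open speak of the compounds shown alone.

In an ADME assay on GES1 cells (Homo sapiens) for inhibition, read by MTT assay, with a stated time of 72 h (a higher number here means a weaker inhibitor, a lower number a stronger inhibitor), compound 1 `Cc1cc(Nc2cc(-c3ccccc3)[nH]n2)n2nc(SCCc3ccccc3)nc2n1` gives 37400 nM. For the measured compounds named here, compound 2 `Cc1cc(Nc2cc(-c3ccccc3)[nH]n2)n2nc(SCC(=O)c3ccccc3)nc2n1` gives 33300 nM, level with compound 1 within the scatter, and these two are the only measured values. Compound 3 `Cc1cc(Nc2cc(-c3ccccc3)[nH]n2)n2nc(SCCCc3ccccc3)nc2n1` carries phenethyl in place of benzoyl on a saturated chain carbon bound to a sulfur. Going by the values given here, one measured step bears on this change, a swap at the same place, and it stayed within the scatter: a 1.1-fold lower number from compound 1 to compound 2 (0.05 log units; within the scatter). No step beyond the scatter is therefore expected in this assay, in either direction. The estimated step is a 1.0-fold lower number from compound 2 to compound 3 (0.00 log units; within the scatter). Compound 3 is expected at 33000 nM, with an estimated range of 16000 nM to 66000 nM.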

Compound 3, half-maximal inhibitory concentration: 40200 nM
Compound 3: middle estimate off by 1.2-fold (0.09 log units), on the low side; measured number inside the range.
By their numbers in this assay, from the lowest: compounds 2, 1 and 3 (each within the scatter of the next).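

In this assay, the carbonyl of the benzoyl group can be lost with no step beyond the scatter: phenethyl in place of benzoyl on a saturated chain carbon bound to a sulfur gives a 1.2-fold higher number from compound 2 to compound 3 (0.08 log units; within the scatter) here. Benzyl in place of phenyl on a saturated chain carbon, two bonds along the chain from a sulfur, gives a 1.1-fold higher number from compound 1 to compound 3 (0.03 log units; within the scatter), so chain length joins the carbonyl among the changes that leave the three numbers level. Nothing measured here offers a reason for this.

On these data alone, whether a basic amine or a carboxylic acid on this chain would shift the number stays open. So does whether any change at this place would matter with a different group on the shared core.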